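Pyridinyl isomers in the 3-hydroxyphenyl series

The compounds below may be only part of what the source reports. "The series", "measured", "known", "first", "only" and "open" are said of these compounds alone.

Measured so far in a functional assay on MDA-MB-231 cells (Homo sapiens) for cytotoxicity, read by ELISA, with a stated time of 2 days; a higher number here means a weaker inhibitor, a lower number a stronger inhibitor:
- compound 1 `Oc1cccc(-c2cc(-c3ccccc3)nc(-c3ccccn3)c2)c1` gives 18700 nM in this assay
- compound 2 `Oc1cccc(-c2cc(-c3ccccc3)nc(-c3cccnc3)c2)c1` gives 22800 nM in this assay

Among the compounds with values here, with only two measured compounds, compound 2 at 22800 nM lies within the scatter of compound 1, its sole neighbour on the scale. The next compound, compound 3 `Oc1cccc(-c2cc(-c3ccccc3)nc(-c3ccncc3)c2)c1`, carries pyridin-4-yl in place of pyridin-3-yl on an aromatic carbon next to the ring nitrogen of the shared core. Within the data shown here, one measured step bears on this, the exchange of pyridin-2-yl for pyridin-3-yl at the same place, which gave a 1.2-fold higher number from compound 1 to compound 2 (0.09 log units; within the scatter) and stayed within the scatter. A single step is thin support, but it offers no reason to expect a real shift. The estimated step is a 1.0-fold lower number from compound 2 to compound 3 (0.02 log units; within the scatter) and no change beyond the scatter is expected in this assay in either direction. For compound 3 the expected value is 22000 nM with an estimated range from 11000 nM to 42000 nM for the measurement.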

Compound 3, half-maximal inhibitory concentration: 12200 nM
Compound 3: the middle estimate sits 1.8-fold (0.26 log units) above what was measured, and the stated range covers the measured number.
By their numbers in this assay, from the lowest: compounds 3, 1 and 2 (each within the scatter of the next).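

With pyridin-4-yl at this position, all three pyridinyl attachments on the shared core can be compared in this assay: the change from pyridin-3-yl gives a 1.9-fold lower number from compound 2 to compound 3 (0.27 log units; within the scatter), and the change from pyridin-2-yl gives a 1.5-fold lower number from compound 1 to compound 3 (0.19 log units; within the scatter). Both steps stay within the scatter, as does the earlier step between the other two isomers, so this assay does not separate the three compounds, and changing the point of attachment of the pyridine ring has no readable effect here. The data shown give no measurement that could explain this flat result.

Still open, going by these compounds, is whether a different kind of group at this position, such as an aminomethyl chain or a carboxylic acid, would give a step beyond the scatter. Also open, on these data alone, is whether replacing the hydroxyl of the 3-hydroxyphenyl group with a methoxy group or an amine would reveal any difference among the pyridinyl isomers.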